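Adding a Methyl to the Fluoro Analogue

The compounds below may be only part of what the source reports. "The series", "measured", "known", "first", "only" and "open" are said of these compounds alone.

For the measured compounds named here, compound 2 `O=c1[nH]c2ccccc2cc1-c1nc2cc(F)ccc2[nH]1` is the one compound of the three measured that gives a number: in a functional assay on SK-OV-3 cells (Homo sapiens) for cytotoxicity, read by MTT assay, with a stated time of 48 h (on this read-out higher numbers stand for weaker inhibition and lower numbers for stronger inhibition), compound 2 gives 18300 nM. Compound 3 `O=c1[nH]c2ccccc2cc1-c1nc2cc([N+](=O)[O-])ccc2[nH]1` reaches only a limit of the assay, > 100000 nM, in this assay. Compound 1 `Cc1ccc2[nH]c(=O)c(-c3nc4cc([N+](=O)[O-])ccc4[nH]3)cc2c1` likewise stops at a limit, > 100000 nM. The step of an at least 5.4-fold higher number from compound 2 to compound 3 (0.73 log units; beyond the scatter) is readable only as a lower bound, while the step that the two limits leave unreadable from compound 1 to compound 3 cannot be read at all, both compounds sitting at the limit of > 100000 nM in this assay, at which 2 of the 3 values shown sit. Compound 4 `Cc1ccc2[nH]c(=O)c(-c3nc4cc(F)ccc4[nH]3)cc2c1` differs from compound 2 by methyl in place of hydrogen on an aromatic carbon. Going by the values given here, the single measured step of that kind is the unreadable one, so no size or direction can be drawn from it, and a step within the scatter is expected. Compound 4 is estimated at 18000 nM, between 7000 nM and 50000 nM. That estimate is expected to mean a 1.0-fold lower number from compound 2 to compound 4 (0.01 log units; within the scatter).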

Compound 4, half-maximal inhibitory concentration: > 100000 nM
Compound 4: no number, only a limit; the forecaster's own chance of this, stated with the estimate: 10%; at least 5.5-fold (0.74 log units) between middle value and limit.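

In this assay, methyl in place of hydrogen on an aromatic carbon now has a readable direction, where the earlier step of this kind gave none: an at least 5.4-fold higher number from compound 2 to compound 4 (0.73 log units; beyond the scatter). This is only a lower bound, as compound 4 stops at a limit of the assay. The step between the two methyl compounds cannot be read, as neither gives a number: the limit of > 100000 nM in this assay, at which 3 of the 4 values shown sit.

Going by these compounds, how far the methyl step really reaches stays open. So does whether a chloro group or an amine on this aromatic carbon would keep a measurable number.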